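A few compounds are considered here, and "the series" means these few. Any claim that something is new, unique, unknown or untested is made for them only; others in the source may bear on it.

In an ADME assay on BEAS-2B cells (Homo sapiens) for cytotoxicity, read by MTT assay, with a stated time of 72 h (on this read-out lower numbers stand for stronger inhibition of growth and higher numbers for weaker inhibition of growth), the measured compounds stand as follows:

Compound 1, `COc1ccc(CNc2nc([Se]C)nc3ccccc23)cc1`: > 100000 nM, a limit of the assay, not a number.
Compound 2, `C[Se]c1nc(N)c2ccccc2n1`: 23600 nM.
Compound 3, `CCCCC[Se]c1nc([Se]CCCCC)c2cccnc2n1`: > 100000 nM, again a limit of the assay.

For compound 1 only that limit is known, which is the limit of > 100000 nM in this assay, at which 2 of the 3 values shown sit. Going by the values given here, no pair of these three compounds differs in a single place, so no measured step is available. Compound 4, `COc1ccc(CNc2nc([SeH])nc3ccccc23)cc1`, differs from compound 1 by hydrogen in place of methyl on a selenium. Among the compounds with values here, with no measured step to lean on, the change is expected to move this assay by at most a modest amount, most likely within the scatter, though a slight shift toward stronger inhibition cannot be excluded. Compound 4 is therefore estimated at 90000 nM, ranging from 20000 nM to 300000 nM. This expectation corresponds to a step of an at least 1.1-fold lower number from compound 1 to compound 4 (0.04 log units; that floor lies within the scatter).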

Compound 4, concentration for 50% growth inhibition: 37400 nM
For compound 4 the middle estimate is 2.4-fold (0.38 log units) above the measured one; the measured number falls inside the stated range.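

In this assay, going by these compounds alone, hydrogen in place of methyl on a selenium gives an at least 2.6-fold lower number from compound 1 to compound 4 (0.42 log units; beyond the scatter) and so provides the first measured step at this position, showing that what sits on this selenium can change growth inhibition. The true step may be larger, because the value for compound 1 is a limit and not a number: the limit of > 100000 nM in this assay, at which 2 of the 4 values shown sit.

The compounds shown leave open how an ethyl group or a longer chain on this selenium would compare. They also leave open whether sulfur in place of selenium would give a similar step.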